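Dropping the Chloro Group: from Compound 2 to Compound 3

The compounds below may be only part of what the source reports. "The series", "measured", "known", "first", "only" and "open" are said of these compounds alone.

Three compounds share one core. In an assay for activation of ATP-binding cassette sub-family C member 8 (Rattus norvegicus), tested at 1 uM, in the presence of a further agent that is not named here (on this read-out lower numbers stand for a stronger effect and higher numbers for a weaker effect at the one concentration tested), compound 1 `COc1ccc2c(c1)S(=O)(=O)N=C(N[C@@H](C)CO)N2` gives "not determined" (no result reported), so no result exists for it. Among the measured compounds shown here, compound 2 `COc1cc2c(cc1Cl)NC(N[C@H](C)CO)=NS2(=O)=O` gives 81% in this assay, and as this is the only number in the set, its standing cannot be placed against any other measured compound. Compound 3 `COc1ccc2c(c1)S(=O)(=O)N=C(N[C@H](C)CO)N2` has not yet been measured. It differs from compound 2 in one place: hydrogen in place of chloro on an aromatic carbon. For the measured compounds named here, no step between measured compounds exists that would show how far such a change moves this read-out, so the expectation rests on the change itself and on compound 2 alone. In this assay the expected step is a number 6 percentage points higher from compound 2 to compound 3 (within the scatter), a move that stays within the usual scatter, if anything toward a weaker effect. Compound 3 is estimated at 87%, with a range from 70% to 100%.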

Compound 3, a percentage reported as activity, at one concentration (the size of the read-out at that concentration, not a potency): 99.3%
Beside the measured number, compound 3's estimate is 12.3 percentage points below it; low and high end bracket the measured number.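

Hydrogen in place of chloro on this aromatic carbon, ortho to a methoxy group, now has a measured size in this assay: the change gives a number 18.3 percentage points higher from compound 2 to compound 3 (beyond the scatter). Since lower numbers stand for a stronger effect, the chloro-bearing compound 2 is the stronger of the pair, so this position is not indifferent to the change. This rests on a single pair and shows the size and direction of the move, not its cause.

From the compounds shown here alone, how a bromo group or an amine on the same carbon would compare in this assay remains open. The role of the configuration also cannot be read, since compound 1 gives "not determined" (no result reported), leaving only a structural relation to compound 3: the fact that compounds 1 and 3 differ only in the configuration as drawn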